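A few compounds are considered here, and "the series" means these few. Any claim that something is new, unique, unknown or untested is made for them only; others in the source may bear on it.

Notes on the series. Compound 1 `CC(=O)Oc1ccccc1C(=O)OCOC(=O)OCCOc1ccc(-c2cc(=S)ss2)cc1`, compound 2 `CC(=O)Oc1ccccc1C(=O)OCOC(=O)Oc1ccc(CCCO[N+](=O)[O-])cc1` and compound 3 `CC(=O)Oc1ccccc1C(=O)OCOC(=O)OCC(CO[N+](=O)[O-])O[N+](=O)[O-]` share one core and have each been run in a physicochemical assay, read by HPLC, with a stated time of 3 h, at pH 1; on this read-out lower numbers stand for a less stable compound and higher numbers for a more stable compound. In this assay compound 1 gives 98%, compound 2 gives 98% and compound 3 gives 98%. Compound 2 thus stands level with compounds 1 and 3 at the digits shown, nearest compound 1 and furthest compound 3, both without change beyond the scatter. Compound 4 `CC(=O)Oc1ccccc1C(=O)OCOC(=O)Oc1ccc(CC(CO[N+](=O)[O-])O[N+](=O)[O-])cc1` has not been run; it differs from compound 2 by nitrooxy in place of hydrogen on a saturated chain carbon bound to two saturated chain carbons. For the measured compounds named here, no step between measured compounds is available to calibrate this change, so no movement beyond the scatter is expected in this assay, because compound 3, already carrying two nitrooxy groups, gives 98%. Compound 4 is estimated at 97%, within 90% to 100%. The expected step is a number 1 percentage points lower from compound 2 to compound 4 (within the scatter).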

Compound 4, percent of the compound remaining: 98%
Beside the measured number, compound 4's estimate is 1 percentage points below it, within the range that was stated.
By their numbers in this assay, from the lowest: compounds 1, 2, 3 and 4 (each within the scatter of the next).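

In this assay there is no change at the digits printed from compound 2 to compound 4 (within the scatter) for nitrooxy in place of hydrogen on a saturated chain carbon bound to two saturated chain carbons. This gives the series its first measured single-place step, with the 3-(nitrooxy)propyl chain and the 2,3-bis(nitrooxy)propyl chain reading alike on the shared core. Nothing available explains this outcome. Going by these compounds, whether an amine or a carboxylic acid in place of that hydrogen, or a longer chain carrying nitrooxy, would also read alike in this assay remains open.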